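Aryl replacement on the ring nitrogen: compound 3 to compound 4

The source may hold more compounds than are shown below. What is called first, only, known or untested is meant among the compounds shown, and "the series" means these compounds.

Measured compounds:
compound 1 `N#CC1=C(N)Oc2c(c3nc4ccccc4nc3c3ccccc23)C12C(=O)N(Cc1cnnn1-c1cc(Cl)ccc1Cl)c1ccccc12` – in a functional assay on MCF7 cells (Homo sapiens) for antiproliferative activity, read by MTT assay, with a stated time of 48 h (a lower number here means a stronger inhibitor, a higher number a weaker inhibitor), compound 1 gives > 50000 nM, a limit of the assay and not a number.
compound 2 `Cc1ccccc1-n1nncc1CN1C(=O)C2(C(C#N)=C(N)Oc3c(N)cc4nc5ccccc5nc4c32)c2ccccc21` – compound 2 gives > 50000 nM, again a limit and not a number.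
compound 3 `N#CC1=C(N)Oc2c(N)cc3nc4ccccc4nc3c2C12C(=O)N(Cc1cnnn1-c1ccccc1Cl)c1ccccc12` – compound 3 gives 34400 nM.

Going by the values given here, compound 3 thus stands as the only real number among the three; the other two values sit at the limit of > 50000 nM in this assay, at which 2 of the 3 values shown sit. Among the compounds with values here, the one measured step, an at least 1.4-fold lower number from compound 2 to compound 3 (0.16 log units; that floor lies within the scatter), is a floor that lies within the scatter, so it teaches nothing about direction.

Compound 4 `CC(=O)Nc1ccc(-n2nncc2CN2C(=O)C3(C(C#N)=C(N)Oc4c(N)cc5nc6ccccc6nc5c43)c3ccccc32)cc1` is the next compound, differing from compound 3 by 4-acetamidophenyl in place of 2-chlorophenyl on an aromatic nitrogen. Within the data shown here, none of the measured steps touches this kind of exchange, and the only step that is measured stays within the scatter. For compound 4 the step of a 1.3-fold higher number from compound 3 to compound 4 (0.12 log units; within the scatter) is therefore expected to be none beyond the scatter. Compound 4 is estimated at 45000 nM, between 15000 nM and 150000 nM, with a real chance that only a limit is reported.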

Compound 4, half-maximal inhibitory concentration: > 50000 nM
Compound 4 gave a limit, no number; the forecaster's own chance of this, stated with the estimate: 55%; middle value at least 1.1-fold (0.04 log units) from the limit.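

In this assay, going by these compounds alone, the first exchange of 2-chlorophenyl for a group carrying a hydrogen-bond donor and acceptor, 4-acetamidophenyl on the aromatic nitrogen, yields only a floor: an at least 1.4-fold higher number from compound 3 to compound 4 (0.16 log units; that floor lies within the scatter). The pair of compound 2 and compound 4 joins two limits and cannot be read, so 4-acetamidophenyl cannot be ranked against 2-chlorophenyl or 2-methylphenyl at this position. What is new is that this larger aryl group also fails to give a number, and the series now rests largely on one ceiling: the limit of > 50000 nM in this assay, at which 3 of the 4 values shown sit.

On these data alone, whether a 4-aminophenyl or 4-carboxyphenyl group on this nitrogen would give a readable number stays open. Also open, as far as these compounds go, is whether a simple alkyl chain in place of the aryl ring would separate from compound 3 by more than the scatter.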